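Swapping the Side Chain of Compound 3

The compounds below may be only part of what the source reports. "The series", "measured", "known", "first", "only" and "open" are said of these compounds alone.

Measured in a functional assay on FaDu cells (Homo sapiens) for antiproliferative activity, read by sulforhodamine B assay, with a stated time of 48 h; a lower number here means a stronger inhibitor, a higher number a weaker inhibitor:
- Compound 1 `CCCCN(C)C(=O)CCCOc1cc(OC)c(OC)c2oc(-c3ccc(OC)cc3)c(O)c(=O)c12`: > 40000 nM (a limit)
- Compound 2 `COc1ccc(-c2oc3c(OC)c(OC)cc(OCCCC(=O)N4CCN(C)CC4)c3c(=O)c2O)cc1`: > 40000 nM (a limit)
- Compound 3 `CCCCN(C)C(=O)CCCCOc1cc(OC)c(OC)c2oc(-c3ccc(OC)cc3)c(O)c(=O)c12`: 22000 nM

Among the compounds with values here, compound 3 gives 22000 nM in this assay, the only true number among the three. The other two values are the limit of > 40000 nM in this assay, at which 2 of the 3 values shown sit.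

Compound 4 `COc1ccc(-c2oc3c(OC)c(OC)cc(OC(C)CN(C)C)c3c(=O)c2O)cc1` carries 1-((dimethylamino)methyl)ethyl in place of 4-(butyl(methyl)carbamoyl)butyl on an oxygen on an aromatic ring, and the count of that change is 1-((dimethylamino)methyl)ethyl in place of 4-(butyl(methyl)carbamoyl)butyl on an oxygen on an aromatic ring.

Two measured steps lead to compound 3: an at least 1.8-fold lower number from compound 1 to compound 3 (0.25 log units; that floor lies within the scatter) and an at least 1.8-fold lower number from compound 2 to compound 3 (0.25 log units; that floor lies within the scatter). Neither floor clears the scatter. The third is a step that the two limits leave unreadable from compound 1 to compound 2. None of these steps exchanges the whole 4-(butyl(methyl)carbamoyl)butyl group, so they give no size for this change, and no step beyond the scatter is expected in either direction.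

The expected step is a 1.1-fold lower number from compound 3 to compound 4 (0.04 log units; within the scatter), and a reading at the limit remains possible. The estimated value for compound 4 is 20000 nM, within an expected range of 6000 nM to 60000 nM.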

Compound 4, half-maximal inhibitory concentration: 5410 nM
For compound 4 the middle estimate is 3.7-fold (0.57 log units) above the measured one; measured number outside the range, below it.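

In this assay, within the data shown here, the exchange on an oxygen on an aromatic ring gives a 4.1-fold lower number from compound 3 to compound 4 (0.61 log units; beyond the scatter), the first step here that both has a readable size and clears the scatter. The same entering group, 1-((dimethylamino)methyl)ethyl, also gives an at least 7.3-fold lower number from compound 2 to compound 4 (0.86 log units; beyond the scatter) and an at least 7.3-fold lower number from compound 1 to compound 4 (0.86 log units; beyond the scatter), so it stands out against all three amide-bearing chains. Those last two steps are floors, set by a limit of the assay and not by a number: the limit of > 40000 nM in this assay, at which 2 of the 4 values shown sit.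

The change removes the amide carbonyl, leaves the group with fewer heavy atoms and adds a branch all at once, so the compounds shown do not say which of these carries the step. An unbranched 2-(dimethylamino)ethyl group or a piperidine-bearing chain on the same oxygen would begin to separate them.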